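Moving the Chlorine Around the Ring

The source may report more compounds than this note shows. Statements on the series, on what has been measured and on what is new or still open speak of the compounds shown alone.

Four compounds share one core and differ only in the group carried on a sulfonamide nitrogen. Compound 1 `O=C1NCCN1c1ccc(S(=O)(=O)Nc2ccc(F)c(F)c2)cc1` is the weakest of the three measured: in a functional assay on M21 cells (Homo sapiens) for antiproliferative activity, read by sulforhodamine B assay, with a stated time of 48 h (on this read-out higher numbers stand for weaker inhibition and lower numbers for stronger inhibition), compound 1 gives 220 nM. Compound 2 `Cc1cccc(NS(=O)(=O)c2ccc(N3CCNC3=O)cc2)c1` gives 69 nM, and compound 3 `O=C1NCCN1c1ccc(S(=O)(=O)Nc2cccc(Cl)c2)cc1` gives 25 nM, the lowest number of the three, so compound 3 is the strongest inhibitor measured so far. The measured steps are a 3.2-fold lower number from compound 1 to compound 2 (0.50 log units; beyond the scatter), an 8.8-fold lower number from compound 1 to compound 3 (0.94 log units; beyond the scatter) and a 2.8-fold lower number from compound 2 to compound 3 (0.44 log units; beyond the scatter), each a modest gain, each beyond the scatter.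

Compound 4 `O=C1NCCN1c1ccc(S(=O)(=O)Nc2ccc(Cl)cc2)cc1` has not yet been measured. It differs from compound 3 by 4-chlorophenyl in place of 3-chlorophenyl on a sulfonamide nitrogen. Among the compounds with values here, none of the measured steps moves a group from one place on the ring to another while leaving the rest unchanged, so none bears directly on this change. Compound 1, which carries the 3,4-difluorophenyl group, gives the weakest number, but that group differs from the others in more than one way and offers only a faint hint. The expectation is a small rise in the number, possibly none beyond the scatter. Compound 4 is therefore expected to give about 50 nM, with a range from 15 nM to 200 nM. This corresponds to an expected step of a 2.0-fold higher number from compound 3 to compound 4 (0.30 log units; within the scatter).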

Compound 4, half-maximal inhibitory concentration: 90 nM
For compound 4 the middle estimate is 1.8-fold (0.26 log units) below the measured one; low and high end bracket the measured number.
By their numbers in this assay, from the lowest: compound 3; then compounds 2 and 4 (each within the scatter of the next); then compound 1.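

Moving the chlorine alone, with the same atoms joined differently, is enough to change the result in this assay: the step is a 3.6-fold higher number from compound 3 to compound 4 (0.56 log units; beyond the scatter), so on the sulfonamide nitrogen it matters where the chlorine sits on the ring, not only that a chlorine is present, and the 3-chlorophenyl group gives the stronger inhibition. The 4-chlorophenyl group also loses the clear edge that the 3-chlorophenyl group holds over the 3-methylphenyl group, as the comparison with that group gives a 1.3-fold higher number from compound 2 to compound 4 (0.12 log units; within the scatter), which leaves the two inside the scatter, while it still improves on the 3,4-difluorophenyl group, with a 2.4-fold lower number from compound 1 to compound 4 (0.39 log units; beyond the scatter). No measurement at hand accounts for the difference between the two chlorine positions.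

The compounds shown leave open how a methoxy group, an amine or a carboxylic acid would fare in place of the chlorine, and whether any of them would match compound 3 at 25 nM. Going by these compounds, it also remains open whether the gap between the two chlorine compounds holds in other cell lines.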